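Shifting a Trifluoromethyl Group Around a Shared Core

The compounds below may be only part of what the source reports. "The series", "measured", "known", "first", "only" and "open" are said of these compounds alone.

Compound 1 `Oc1ccccc1-c1cc(-c2cccc(C(F)(F)F)c2)cc(-c2ccccc2O)n1`: in a functional assay on DU-145 cells (Homo sapiens) for inhibition (on this read-out lower numbers stand for stronger inhibition and higher numbers for weaker inhibition), compound 1 gives > 50000 nM, which is a limit of the assay and not a number.
Compound 2 `Oc1ccccc1-c1cc(-c2ccc(C(F)(F)F)cc2)cc(-c2ccccc2O)n1`: in this assay compound 2 gives > 50000 nM, again a limit and not a number.
Compound 3 `Oc1cccc(-c2cc(-c3cccc(C(F)(F)F)c3)cc(-c3ccccc3O)n2)c1`: in this assay compound 3 gives 13000 nM.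

Compound 3 is the only one of the three with a number; the other two sit at the limit of > 50000 nM in this assay, at which 2 of the 3 values shown sit. Compound 3 differs from compound 1 by 3-hydroxyphenyl in place of 2-hydroxyphenyl on an aromatic carbon, and this change gives an at least 3.8-fold lower number from compound 1 to compound 3 (0.58 log units; beyond the scatter). The other change seen so far, from compound 1 to compound 2, is 4-(trifluoromethyl)phenyl in place of 3-(trifluoromethyl)phenyl on an aromatic carbon; it gives a step that the two limits leave unreadable from compound 1 to compound 2.

Compound 4 `Oc1cccc(-c2cc(-c3ccc(C(F)(F)F)cc3)cc(-c3ccccc3O)n2)c1` has not yet been measured in this assay. It differs from compound 3 by 4-(trifluoromethyl)phenyl in place of 3-(trifluoromethyl)phenyl on an aromatic carbon. This is the same kind of change as that from compound 1 to compound 2, but not the same: in compound 1 the place is meta to two 2-hydroxyphenyl groups, whereas in compound 3 it is meta to a 2-hydroxyphenyl group and meta to a 3-hydroxyphenyl group.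

Because the earlier step that the two limits leave unreadable from compound 1 to compound 2 has no readable size, the expectation for compound 4 rests on compound 3 alone and on its value 13000 nM, taken with a step expected to be around a 1.2-fold higher number from compound 3 to compound 4 (0.06 log units; within the scatter). Compound 4 is therefore estimated to give about 15000 nM in this assay, most likely between 5000 nM and 50000 nM.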

Compound 4, half-maximal inhibitory concentration: > 50000 nM
Compound 4 was reported as a limit; the forecaster's own chance of this, stated with the estimate: 25%; at least 3.3-fold (0.52 log units) between middle value and limit.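

On the core of compound 3, putting 4-(trifluoromethyl)phenyl in place of 3-(trifluoromethyl)phenyl gives an at least 3.8-fold higher number from compound 3 to compound 4 (0.58 log units; beyond the scatter), so on this core the position of the trifluoromethyl group matters in this assay, and the true size of the step could be larger than the printed minimum. In this assay compound 4 gives > 50000 nM, which is a limit and not a number. Whether the change carries over from one core to the other remains unshown, because on the core of compound 1 the same change runs from one limit to another, and that step, like the one from compound 2 to compound 4, cannot be read: the limit of > 50000 nM in this assay, at which 3 of the 4 values shown sit.

The compounds shown leave open what other groups would do at the place of the trifluoromethyl group on this phenyl ring, such as an amine or a carboxylic acid, and whether any of them would give a lower number than compound 3, which gives 13000 nM in this assay. Also open, from the compounds shown here alone, is what would follow if the remaining 2-hydroxyphenyl group of compound 3 became a second 3-hydroxyphenyl group.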